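Series notes: the 3-carboxyazetidin-1-yl step

This account rests on a few compounds, and the source may have more. Where it says the series, first, only, none or still open, it means among the compounds named here.

Measured in an ADME assay on NCM460 cells (Homo sapiens) for cytotoxicity, read by CCK-8 assay, with a stated time of 48 h; on this read-out higher numbers stand for weaker inhibition and lower numbers for stronger inhibition:
Compound 1 (`COc1ccc(/C=C\c2cc(OC)c(OC)c(OC)c2)cc1OCc1ccc(CNC(C)(C)C(=O)O)cc1`) gives > 50000 nM as a limit.
Compound 2 (`COc1ccc(/C=C\c2cc(OC)c(OC)c(OC)c2)cc1OCc1ccc(CN[C@H](C(=O)O)[C@H](C)O)cc1`) gives > 50000 nM as a limit.

Compound 2 has no numerical value, and its place in the series is defined only by its limit. Both measured compounds share one reading, the limit of > 50000 nM in this assay, at which 2 of the 2 values shown sit, in this set.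

Compound 3 (`COc1ccc(/C=C\c2cc(OC)c(OC)c(OC)c2)cc1OCc1ccc(CN2CC(C(=O)O)C2)cc1`) is still to be measured. The change is 3-carboxyazetidin-1-yl in place of (1-carboxy-2-hydroxypropyl)amino on a saturated chain carbon bound to an aromatic carbon in full. The group that enters carries one four-membered non-aromatic ring with 1 hetero atom, while the group that leaves has no ring.

Going by the values given here, the one measured step that bears on this is a step that the two limits leave unreadable from compound 1 to compound 2 on the amine nitrogen substituent. It runs from one limit to another and gives no size to carry over.

The expectation therefore rests on compound 2 with its limit of > 50000 nM as the only anchor. No readable change in either direction is expected in this assay, and a further limit is the likeliest report. The expected step is a step that the limit leaves unreadable from compound 2 to compound 3 on this basis. For compound 3 the estimate is 60000 nM with 25000 nM to 150000 nM as the expected range.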

Compound 3, half-maximal inhibitory concentration: > 50000 nM
Compound 3 was reported as a limit (the forecaster's own chance of this, stated with the estimate: 80%); the middle value is on the limit's open side.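

In this assay compound 3 gives > 50000 nM, which is a limit. Going by these compounds alone, no step among compound 1, compound 2 and compound 3 can therefore be read. The compounds shown leave open how far each lies beyond the limit, and whether 3-carboxyazetidin-1-yl differs at all from (1-carboxy-2-hydroxypropyl)amino in this assay.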